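From 4-carbamoylphenyl to 1H-indol-6-yl

The source may hold more compounds than are shown below. What is called first, only, known or untested is meant among the compounds shown, and "the series" means these compounds.

Of the compounds shown here, three sharing one core have been measured so far in a functional assay on HeLa cells (Homo sapiens) for antiproliferative activity, read by CCK-8 assay, with a stated time of 72 h; on this read-out lower numbers stand for stronger inhibition and higher numbers for weaker inhibition. Compound 1 `COc1ccc(-c2cncnc2-c2cc(OC)c(OC)c(OC)c2)cc1` gives 1140 nM, and compound 2 `COc1ccc(-c2cncnc2-c2cc(OC)c(OC)c(OC)c2)cc1Cl` gives 320 nM. That change is a 3.6-fold lower number from compound 1 to compound 2 (0.55 log units; beyond the scatter), a modest step, and it shows that this aromatic group can move the number.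

Compound 3 `COc1cc(-c2ncncc2-c2ccc(C(N)=O)cc2)cc(OC)c1OC` gives > 100000 nM, which is a limit of the assay and not a number. This places compound 3 at the limit of > 100000 nM in this assay, at which 1 of the 3 values shown sits.

Compound 4 `COc1cc(-c2ncncc2-c2ccc3cc[nH]c3c2)cc(OC)c1OC` carries 1H-indol-6-yl in place of 4-carbamoylphenyl on an aromatic carbon. The group that leaves is the one that entered in the two large measured steps: an at least 87-fold higher number from compound 1 to compound 3 (1.94 log units; beyond the scatter) and an at least 310-fold higher number from compound 2 to compound 3 (2.49 log units; beyond the scatter). Neither step tests the new group directly, so the comparison is only indirect. Even so, those two steps suggest that removing 4-carbamoylphenyl could undo much of the loss, so a large step toward a lower number is expected in this assay. The estimated step is an at least 200-fold lower number from compound 3 to compound 4 (2.30 log units; beyond the scatter). For compound 4 the estimated value is 500 nM, with an expected range from 50 nM to 5000 nM.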

Compound 4, half-maximal inhibitory concentration: 770 nM
Compound 4: the middle estimate sits 1.5-fold (0.19 log units) below what was measured, and the stated range covers the measured number.
By their numbers in this assay, from the lowest: compound 2; then compounds 4 and 1 (each within the scatter of the next). At a limit, above all of these: compound 3.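

Among the compounds shown, only 4-methoxyphenyl and 3-chloro-4-methoxyphenyl had given a measurable number at this place, and each has a single six-membered aromatic ring. In this assay, 1H-indol-6-yl, with its added five-membered aromatic ring, also works here and restores activity (an at least 120-fold lower number from compound 3 to compound 4 (2.11 log units; beyond the scatter)), matching the plain methoxyphenyl group within the scatter (a 1.5-fold lower number from compound 1 to compound 4 (0.17 log units; within the scatter)) but not the chlorinated one (a 2.4-fold higher number from compound 2 to compound 4 (0.38 log units; beyond the scatter)). Compound 3 is only a limit of the assay and not a number, so the largest step gives a lower bound rather than an exact size: the limit of > 100000 nM in this assay, at which 1 of the 4 values shown sits.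

On these data alone, what remains open is whether the loss in compound 3 belongs to the carbamoyl group alone, which a carboxylic acid or an amine on the same phenyl ring would help to test. It is also unclear whether 1H-indol-5-yl would serve as well as 1H-indol-6-yl, or whether a chloro group on the indole would bring the same gain it brought to compound 2.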